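This account rests on a few compounds, and the source may have more. Where it says the series, first, only, none or still open, it means among the compounds named here.

Compound 1 `Cc1cc(C#N)cc(C)c1Oc1nc(Nc2ccc(C#N)cc2)ncc1-c1ccco1`: in an ADME assay on MT4 cells (Homo sapiens) for cytotoxicity, read by MTT assay, with a stated time of 5 days (on this read-out higher numbers stand for lower toxicity in this test and lower numbers for higher toxicity in this test), compound 1 gives > 306000 nM, a limit of the assay rather than a number.
Compound 2 `Cc1cc(C#N)cc(C)c1Oc1nc(Nc2ccc(C#N)cc2)ncc1-c1ccsc1`: compound 2 gives 3920 nM.
Compound 3 `Cc1cc(C#N)cc(C)c1Oc1nc(Nc2ccc(C#N)cc2)ncc1-c1ccc(-c2ccccc2)cc1`: compound 3 gives > 253000 nM, again a limit and not a number.

Compound 3 thus sits at the limit of > 253000 nM in this assay, at which 1 of the 3 values shown sits, and a second value in the set is also a limit, (the limit of > 306000 nM in this assay, at which 1 of the 3 values shown sits). Compound 4 `Cc1cc(C#N)cc(C)c1Oc1nc(Nc2ccc(C#N)cc2)ncc1-c1ccc(N)cc1` differs from compound 3 by amino in place of phenyl on an aromatic carbon. Going by the values given here, no measured step involves an amino group. The step of an at least 64-fold higher number from compound 2 to compound 3 (1.80 log units; beyond the scatter) shows that a change at this position can be large, whereas a step that the two limits leave unreadable from compound 1 to compound 3 cannot be read. The direction for compound 4 is therefore open and the range wide. Compound 4 is estimated at 80000 nM, between 8000 nM and 300000 nM, an expected step of an at least 3.1-fold lower number from compound 3 to compound 4 (0.50 log units; beyond the scatter).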

Compound 4, half-maximal cytotoxic concentration: 310 nM
Compound 4: middle estimate off by 260-fold (2.41 log units), on the high side; measured number outside the range, below it.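

Going by these compounds alone, the 4-aminophenyl group of compound 4 gives the lowest number at this position so far in this assay, with a step of an at least 810-fold lower number from compound 3 to compound 4 (2.91 log units; beyond the scatter) and thus far more than the phenyl-to-amino swap might suggest. It also reaches below the thiophen-3-yl group, with a 13-fold lower number from compound 2 to compound 4 (1.10 log units; beyond the scatter) and the furan-2-yl group, with an at least 980-fold lower number from compound 1 to compound 4 (2.99 log units; beyond the scatter) as the remaining step. Within the data shown here, an amino group para to a large group can therefore outdo thiophen-3-yl, the one earlier group with a measured number. Nothing measured here bears on why the number falls. As far as these compounds go, whether a dimethylamino group or a carboxylic acid in place of the amino would follow compound 4 stays open.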